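A few compounds are considered here, and "the series" means these few. Any claim that something is new, unique, unknown or untested is made for them only; others in the source may bear on it.

Compound 1, `O=[N+]([O-])c1cc(C(F)(F)F)cc([N+](=O)[O-])c1Oc1ccccc1/C=N\OCc1ccccc1`, gives 1470 nM in a functional assay on A549 cells (Homo sapiens) for antiproliferative activity, read by MTT assay, with a stated time of 48 h; a higher number here means a weaker inhibitor, a lower number a stronger inhibitor.
Compound 2, `O=[N+]([O-])c1cc(C(F)(F)F)cc([N+](=O)[O-])c1Oc1ccccc1/C=N\OCc1ccccc1F`, gives 860 nM in this assay.
Compound 3, `O=[N+]([O-])c1cc(C(F)(F)F)cc([N+](=O)[O-])c1Oc1c(Cl)cc(Cl)cc1/C=N\OCc1ccccc1`, gives 1450 nM in this assay.

Compound 2 carries one change against compound 1: fluoro in place of hydrogen on an aromatic carbon. This gave a 1.7-fold lower number from compound 1 to compound 2 (0.23 log units; within the scatter), a step too small to count as a real difference. Compound 3 has a different core, and the difference between the two cores is not broken down here. The unmeasured compound 4, `O=[N+]([O-])c1cc(C(F)(F)F)cc([N+](=O)[O-])c1Oc1c(Cl)cc(Cl)cc1/C=N\OCc1ccccc1F`, carries the same change against compound 3: fluoro in place of hydrogen on an aromatic carbon. The same change on a different core is expected to give a step of about the same size, so a 1.6-fold lower number from compound 3 to compound 4 (0.21 log units; within the scatter) is estimated for compound 4 in this assay, resting on the step seen between compound 1 and compound 2. Compound 4 is therefore expected to give about 900 nM in this assay, most likely between 450 nM and 1800 nM.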

Compound 4, half-maximal inhibitory concentration: 1230 nM
Beside the measured number, compound 4's estimate is 1.4-fold (0.14 log units) below it; the measured number falls inside the stated range.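

In this assay, the second core also gave only a 1.2-fold lower number from compound 3 to compound 4 (0.07 log units; within the scatter) when fluoro replaced hydrogen on an aromatic carbon, turning benzyl into 2-fluorobenzyl. Set beside the first core, the change carries over with no detectable difference between the two cores: the same change on two cores in this assay, a 1.7-fold lower number (0.23 log units; within the scatter) from compound 1 to compound 2 and a 1.2-fold lower number (0.07 log units; within the scatter) from compound 3 to compound 4, 1.4-fold (0.16 log units) apart, within the scatter of two such steps. This shows that the change does little on either core, but it does not show that fluoro truly lowers the number on either one, nor that the two cores would respond alike to a change with a larger effect.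

The compounds shown leave open whether a different group in the same place, such as a methoxy group or an amine, would give a step beyond the scatter. They also leave open whether such a step would be the same size on both cores.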